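A few compounds are considered here, and "the series" means these few. Any claim that something is new, unique, unknown or untested is made for them only; others in the source may bear on it.

Of the compounds shown here, three sharing one core have so far been measured in a functional assay on HepG2 cells (Homo sapiens) for antiproliferative activity, read by CCK-8 assay, with a stated time of 72 h, tested at 2 uM; on this read-out higher numbers stand for a stronger effect at the one concentration tested and lower numbers for a weaker effect. Compound 1 `CCCCn1cnc2c(Nc3ccccc3)nc(NCOCc3ccc(/C=C/C(=O)Nc4ccccc4N)cc3)nc21` gives 27.9%. Compound 2 `CC(C)n1cnc2c(Nc3ccccc3)nc(NCOCc3ccc(C(=O)Nc4ccccc4N)cc3)nc21` gives 6.58%. Compound 3 `CC(C)n1cnc2c(Nc3ccccc3)nc(NCOCc3ccc(/C=C/C(=O)Nc4ccccc4N)cc3)nc21` gives 1.46%, the lowest of the three numbers, though its gap to compound 2 lies within the scatter, while its gap to compound 1 lies beyond it. Compound 4 `Nc1ccccc1NC(=O)/C=C/c1ccc(COCNc2nc(Nc3ccccc3)c3ncn(C4CCCC4)c3n2)cc1` has not yet been measured. It differs from compound 3 in one place: cyclopentyl in place of isopropyl on an aromatic nitrogen. Going by the values given here, of the measured steps, only the one that changes the group on the same aromatic nitrogen bears on this, namely a number 26.4 percentage points lower from compound 1 to compound 3 (beyond the scatter). The step of a number 5.1 percentage points lower from compound 2 to compound 3 (within the scatter) concerns another position and offers no guidance here. Because a number 26.4 percentage points lower from compound 1 to compound 3 (beyond the scatter) was modest and beyond the scatter, a change in the opposite sense on that nitrogen, with cyclopentyl entering for isopropyl, is expected to bring the number for compound 4 up, by roughly a number 16.5 percentage points higher from compound 3 to compound 4 (beyond the scatter). Compound 4 is therefore estimated at 18%, with a range from 2% to 40%.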

Compound 4, a percentage reported as inhibition, at one concentration (the size of the read-out at that concentration, not a potency): 2.93%
Compound 4: middle estimate off by 15.1 percentage points, on the high side, and the stated range covers the measured number.
By their numbers in this assay, from the lowest: compounds 3, 4 and 2 (each within the scatter of the next); then compound 1.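

In this assay, replacing isopropyl with cyclopentyl on this aromatic nitrogen gives a number 1.5 percentage points higher from compound 3 to compound 4 (within the scatter), so adding a five-membered non-aromatic ring of carbon only and more heavy atoms does not separate the two compounds. The comparison with the butyl compound reads a number 25 percentage points lower from compound 1 to compound 4 (beyond the scatter), much like a number 26.4 percentage points lower from compound 1 to compound 3 (beyond the scatter), so of the three groups tried on this nitrogen, butyl alone stands apart, while cyclopentyl and isopropyl cannot be told apart. No measurement at hand explains this difference.

As far as these compounds go, it remains open whether a longer chain such as hexyl, or a butyl chain ending in an amine, would match or exceed compound 1. Also unresolved is whether butyl would stand apart in the same way alongside the (2-aminophenyl)carbamoyl group of compound 2.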